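The source may report more compounds than this note shows. Statements on the series, on what has been measured and on what is new or still open speak of the compounds shown alone.

Measured compounds in an assay on COS-7 cells for inhibition of sodium/nucleoside cotransporter 2 (Homo sapiens), read by scintillation counting, in the presence of a further agent that is not named here; a lower number here means a stronger inhibitor, a higher number a weaker inhibitor:
compound 1 `Nc1ncnc2c1nc(NCc1ccccc1Cl)n2[C@@H]1O[C@H](CO)[C@@H](O)[C@H]1O` gives 5700 nM
compound 2 `Nc1ncnc2c1nc(NCc1ccccc1-c1ccccc1)n2[C@@H]1O[C@H](CO)[C@@H](O)[C@H]1O` gives > 100000 nM, a limit of the assay
compound 3 `CCCCCOC(=O)OC[C@H]1O[C@@H](n2cnc3c(N)ncnc32)[C@H](O)[C@@H]1O` gives > 100000 nM, a limit of the assay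

For the measured compounds named here, compound 1 is the only compound of the three with a measured number in this assay; compound 2 and compound 3 each reach only the limit (the limit of > 100000 nM in this assay, at which 2 of the 3 values shown sit). The step to compound 4 `Cc1cccc(CNc2nc3c(N)ncnc3n2[C@@H]2O[C@H](CO)[C@@H](O)[C@H]2O)c1` is 3-methylphenyl in place of 2-chlorophenyl on a saturated chain carbon bound to a nitrogen on an aromatic ring. Going by the values given here, the one measured step that bears on this part of the molecule is an at least 17-fold higher number from compound 1 to compound 2 (1.24 log units; beyond the scatter), where a phenyl entered in place of the chloro and the signal was lost. Compound 4 instead carries a methyl, and the substituent sits at a different position of the ring as named above, so that step is only a partial guide. A loss of potency of some size is expected for compound 4, roughly a 2.1-fold higher number from compound 1 to compound 4 (0.32 log units; beyond the scatter), though it may well stay within the scatter. The expected value for compound 4 in this assay is 12000 nM, with a range from 3000 nM to 60000 nM.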

Compound 4, half-maximal inhibitory concentration: 19000 nM
The estimate for compound 4 lay 1.6-fold (0.20 log units) below the measured number; the range from low to high includes it.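

In this assay, the change from (2-chlorobenzyl)amino to (3-methylbenzyl)amino gives a 3.3-fold higher number from compound 1 to compound 4 (0.52 log units; beyond the scatter), so compound 4 is a weaker inhibitor, though only modestly. The earlier step at this part of the molecule, an at least 17-fold higher number from compound 1 to compound 2 (1.24 log units; beyond the scatter), ended at a limit and showed only that the signal could vanish. Compound 4 shows that this ring can carry a different small group and still give a real number, well clear of the ceiling that compound 2 and compound 3 reached: the limit of > 100000 nM in this assay, at which 2 of the 4 values shown sit.

Because the group and its place on the ring changed together, the compounds shown cannot say which of the two accounts for the step. As far as these compounds go, how a methoxy group, an amine or a carboxylic acid on this ring would read also remains open.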